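A 2-fluorophenyl swap in a narrow growth-inhibition series

A few compounds are considered here, and "the series" means these few. Any claim that something is new, unique, unknown or untested is made for them only; others in the source may bear on it.

Measured so far in a functional assay on DU-145 cells (Homo sapiens) for inhibition, read by trypan blue exclusion, with a stated time of 96 h; on this read-out higher numbers stand for weaker inhibition of growth and lower numbers for stronger inhibition of growth:
- compound 1 `Cc1ccc(CS/C(=C/c2ccc(O)cc2)C(=O)c2ccc(Cl)cc2)cc1` gives 10000 nM
- compound 2 `Cc1ccc(CS/C(=C/c2ccc(F)c(C)c2)C(=O)c2ccc(Cl)cc2)cc1` gives 25000 nM
- compound 3 `Cc1ccc(CS/C(=C/c2cc(C)ccc2C)C(=O)c2ccc(Cl)cc2)cc1` gives 10000 nM

Compound 3 stands level with compound 1, and the two share the lowest number of the three. The next compound is compound 4 `Cc1ccc(CS/C(=C/c2ccccc2F)C(=O)c2ccc(Cl)cc2)cc1`, which carries 2-fluorophenyl in place of 2,5-dimethylphenyl on a double-bonded chain carbon bound to a double-bonded chain carbon. The measured swaps at this same place bear on it. Of these, a 2.5-fold higher number from compound 1 to compound 2 (0.40 log units; beyond the scatter) and a 2.5-fold lower number from compound 2 to compound 3 (0.40 log units; beyond the scatter) were modest, while no change at the digits printed from compound 1 to compound 3 (within the scatter) stayed within the scatter. Among the measured compounds shown here, no measured compound carries 2-fluorophenyl. For the measured compounds named here, compound 2, the only measured compound with fluorine in this group, has the highest number at 25000 nM so any movement is expected to be slightly upward. The estimated step is a 1.4-fold higher number from compound 3 to compound 4 (0.15 log units; within the scatter) and it is expected to stay within the scatter. In this assay the estimate for compound 4 is 14000 nM with an expected range from 7000 nM to 30000 nM as the likely span.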

Compound 4, concentration for 50% growth inhibition: 10000 nM
Compound 4: middle estimate off by 1.4-fold (0.15 log units), on the high side; the range from low to high includes it.
By their numbers in this assay, from the lowest: compounds 1, 3 and 4 (each within the scatter of the next); then compound 2.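

In this assay, moving to 2-fluorophenyl at this place left the number unmoved, with no change at the digits printed from compound 3 to compound 4 (within the scatter) and no change at the digits printed from compound 1 to compound 4 (within the scatter) at the digits printed. Fluorine on this ring therefore does not by itself go with the higher number of compound 2, as a 2.5-fold lower number from compound 2 to compound 4 (0.40 log units; beyond the scatter) shows, and among these four compounds only the 4-fluoro-3-methylphenyl group stands apart from the others. No supporting evidence bears on why these groups read alike in this assay.

All four compounds carry a carbon-only aromatic ring at this place and none falls clearly below the shared level of compounds 1, 3 and 4. On these data alone, it remains open whether a ring bearing an amine or a carboxylic acid, or a longer chain in place of the ring, would move the number in either direction.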